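A difluorophenyl swap among compounds at the limit

The source may report more compounds than this note shows. Statements on the series, on what has been measured and on what is new or still open speak of the compounds shown alone.

Measured compounds, each value a limit of the assay:
Compound 1 `COc1cc(-c2cc(/C=C/C(=O)c3ccc(N)cc3)[nH]n2)cc(OC)c1OC`: > 100000 nM
Compound 2 `COc1cc(-c2cc(/C=C/C(=O)c3ccc(Cl)c(Cl)c3)[nH]n2)cc(OC)c1OC`: > 100000 nM
Compound 3 `COc1ccc(C(=O)/C=C/c2cc(-c3cc(OC)c(OC)c(OC)c3)n[nH]2)cc1`: > 100000 nM

In a functional assay on MOLT-4 cells (Homo sapiens) for inhibition, read by sulforhodamine B assay, with a stated time of 48 h (a lower number here means that less compound is tolerated, a higher number that more compound is tolerated), compound 1 gives > 100000 nM as a limit and not a number. Going by the values given here, the whole series so far is the limit of > 100000 nM in this assay, at which 3 of the 3 values shown sit, and nothing finer. Compound 4 `COc1cc(-c2cc(/C=C/C(=O)c3ccc(F)c(F)c3)[nH]n2)cc(OC)c1OC` carries 3,4-difluorophenyl in place of 4-aminophenyl on a carbonyl carbon, and the count of that change is 3,4-difluorophenyl in place of 4-aminophenyl on a carbonyl carbon with the shared core left as it was. The measured change closest in kind is a step that the two limits leave unreadable from compound 1 to compound 2 and the other two are a step that the two limits leave unreadable from compound 1 to compound 3 and a step that the two limits leave unreadable from compound 2 to compound 3 so none of them offers a size to carry over. Compound 2, the nearest relative, stops at > 100000 nM which is likewise a limit. The expected outcome is a number no higher from compound 1 to compound 4 (the limit leaves the size open) and thus no shift beyond the scatter in this assay in either direction. For compound 4 the estimate is 100000 nM with an expected range from 50000 nM to 200000 nM and the assay will most likely report only a limit.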

Compound 4, concentration lethal to 50% of the cells: > 100000 nM
Compound 4 gave a limit, no number; the forecaster's own chance of this, stated with the estimate: 85%; the middle value sits exactly at the limit.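

In this assay compound 4 gives > 100000 nM, a limit and not a number, so its steps from compound 1, compound 2 and compound 3 cannot be read. The compounds shown leave open how any one of them compares with another, since all stop at the same limit: the limit of > 100000 nM in this assay, at which 4 of the 4 values shown sit.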